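One ring exchanged: from compound 1 to compound 4

The source may report more compounds than this note shows. Statements on the series, on what has been measured and on what is new or still open speak of the compounds shown alone.

Measured so far in a physicochemical assay for solubility, read by LC-MS, in phosphate buffer, with a stated time of 24 h, at pH 7.4; on this read-out higher numbers stand for higher solubility and lower numbers for lower solubility:
- compound 1 `Cn1cc(-c2cnc(NCc3c(F)ccc4c3CCO4)c3cn[nH]c(=O)c23)cn1`: 1000 nM
- compound 2 `Cc1ncccc1-c1cnc(NCc2c(F)ccc3c2CCO3)c2nn(CC#N)c(=O)n12`: 4000 nM
- compound 3 `Fc1ccc2c(c1CNc1ncc(Oc3ccccc3)c3nncn13)CCO2`: 8000 nM

Compound 1 gives the lowest of the three numbers. Its nearest neighbour, compound 2, stands higher at 4000 nM, and compound 3 stands highest at 8000 nM. Both gaps lie beyond the usual scatter of repeated measurements. These three compounds differ in more than one place, however, so their gaps do not show what any single change does.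

Compound 4 `Cc1ncc(-c2cnc(NCc3c(F)ccc4c3CCO4)c3cn[nH]c(=O)c23)n1C` keeps the core of compound 1 and has not yet been measured. The change is 1,2-dimethyl-1H-imidazol-5-yl in place of 1-methyl-1H-pyrazol-4-yl on an aromatic carbon. Both rings are five-membered and aromatic with 2 hetero atoms, and neither carries a net charge.

Among the compounds with values here, with no measured single-place step to draw on, the expectation remains tentative. A modest upward move is expected in this assay, with the estimated step being a 3.0-fold higher number from compound 1 to compound 4 (0.48 log units; beyond the scatter). The estimate for compound 4 is 3000 nM, with an expected range from 800 nM to 12000 nM.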

Compound 4, solubility: 15000 nM
Compound 4: middle estimate off by 5.0-fold (0.70 log units), on the low side; measured number outside the range, above it.
By their numbers in this assay, from the lowest: compound 1; then compounds 2, 3 and 4 (each within the scatter of the next, the first and the last beyond it).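

In this assay, within the data shown here, placing 1,2-dimethyl-1H-imidazol-5-yl in place of 1-methyl-1H-pyrazol-4-yl on the aromatic carbon gives a 15-fold higher number from compound 1 to compound 4 (1.18 log units; beyond the scatter), the first step in this set that can be read at a single place, and a large one. It shows that the read-out at this position can depend strongly on which five-membered aromatic ring is attached, even though both rings have 2 hetero atoms, the same counts of hydrogen-bond donors and acceptors, and no net charge, and the entering ring has only one more heavy atom, a carbon. No measured property is available to account for the step.

The compounds shown do not separate the added methyl from the altered ring itself, and a comparison with 1-methyl-1H-imidazol-5-yl, which lacks the second methyl, would be needed to tell these apart. They also leave open whether the same exchange would have a similar effect on the core of compound 2 or compound 3, and how a ring of another kind, such as morpholine, would behave at this position.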